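Aryl swap on the aromatic nitrogen: from compound 2 to compound 3

A few compounds are considered here, and "the series" means these few. Any claim that something is new, unique, unknown or untested is made for them only; others in the source may bear on it.

Measured so far in a functional assay on A549 cells (Homo sapiens) for antiproliferative activity, read by MTT assay, with a stated time of 48 h; on this read-out higher numbers stand for weaker inhibition and lower numbers for stronger inhibition:
compound 1 `N#CC1=C(N)Oc2c(c3nc4ccccc4nc3c3ccccc23)C12C(=O)N(Cc1cnnn1-c1ccc(F)c(Cl)c1)c1ccccc12` — > 50000 nM (a limit, not a number)
compound 2 `CCOc1ccccc1-n1nncc1CN1C(=O)C2(C(C#N)=C(N)Oc3c(N)cc4nc5ccccc5nc4c32)c2ccccc21` — > 50000 nM (a limit, not a number)

Compound 1 gives > 50000 nM in this assay, which is a limit of the assay rather than a measured number. Compound 2 likewise returns > 50000 nM in this assay, again only a limit. For the measured compounds named here, compound 2 therefore stands at the limit of > 50000 nM in this assay, at which 2 of the 2 values shown sit; no number separates it from compound 1, and no measured step between the two is available.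

Compound 3 `N#CC1=C(N)Oc2c(N)cc3nc4ccccc4nc3c2C12C(=O)N(Cc1cnnn1-c1ccc(Cl)cc1[N+](=O)[O-])c1ccccc12` is the next member. It differs from compound 2 by 4-chloro-2-nitrophenyl in place of 2-ethoxyphenyl on an aromatic nitrogen

Going by the values given here, with both known values sitting at the limit, the series gives no measured step from which the size of this change could be read. The step from compound 2 to compound 3 in this assay is expected to be a number no higher from compound 2 to compound 3 (the limit leaves the size open), that is, none beyond the scatter. Compound 3 is estimated at 50000 nM in this assay, with a range of 15000 nM to 100000 nM, and is expected most likely to be reported only as a limit again.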

Compound 3, half-maximal inhibitory concentration: > 50000 nM
Compound 3 was reported as a limit; the forecaster's own chance of this, stated with the estimate: 75%; the middle value sits exactly at the limit.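

In this assay compound 3 gives > 50000 nM, a limit of the assay and not a number. No step between compound 2 and compound 3 can be read, since all the compounds share one position: the limit of > 50000 nM in this assay, at which 3 of the 3 values shown sit.

The compounds shown leave open whether any aryl group on the aromatic nitrogen gives a measurable value.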